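The compounds below may be only part of what the source reports. "The series", "measured", "known", "first", "only" and "open" are said of these compounds alone.

Measured in a functional assay on T-24 cells (Homo sapiens) for antiproliferative activity, read by MTT assay, with a stated time of 48 h; a higher number here means a weaker inhibitor, a lower number a stronger inhibitor:
- Compound 1 `O=C(Nc1cccc(CNc2nccnc2Cl)c1)Nc1ccc(F)c(Cl)c1`: 4990 nM
- Compound 2 `O=C(Nc1cccc(CNc2nccnc2Cl)c1)NC1CCCC1`: > 40000 nM (a limit)
- Compound 3 `O=C(Nc1cccc(CNc2nccnc2Cl)c1)Nc1cccc(C(F)(F)F)c1`: 5080 nM

Compound 4 `Cc1ccc(NC(=O)Nc2cccc(CNc3nccnc3Cl)c2)cc1Cl` has not yet been measured.

Compound 2 has no numerical value and stands at the limit of > 40000 nM in this assay, at which 1 of the 3 values shown sits.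

Compound 4 has 3-chloro-4-methylphenyl in place of cyclopentyl on an amide-type nitrogen.

The nearest measured step is the one that put cyclopentyl in place of 3-chloro-4-fluorophenyl, an at least 8.0-fold higher number from compound 1 to compound 2 (0.90 log units; beyond the scatter). This step lies beyond the scatter, and since it ends at a limit, its true size is not known. Compound 4 reverses a closely similar change, so a lower number is expected in this assay. The phenyl-bearing compounds offer a guide to the level: compound 1 gives 4990 nM and compound 3 gives 5080 nM, and these two values nearly coincide.

The expected change is an at least 8.0-fold lower number from compound 2 to compound 4 (0.90 log units; beyond the scatter).

For compound 4 the estimated value is 5000 nM, with an expected range from 2000 nM to 12000 nM.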

Compound 4, half-maximal inhibitory concentration: 7390 nM
Beside the measured number, compound 4's estimate is 1.5-fold (0.17 log units) below it, within the range that was stated.
By their numbers in this assay, from the lowest: compounds 1, 3 and 4 (each within the scatter of the next). At a limit, above all of these: compound 2.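

In this assay, for the compounds shown here, 3-chloro-4-methylphenyl in place of cyclopentyl on the amide-type nitrogen gives an at least 5.4-fold lower number from compound 2 to compound 4 (0.73 log units; beyond the scatter), so a second substituted phenyl group, not only the one in compound 1, stands clear of cyclopentyl at this position. Methyl in place of fluoro on an aromatic carbon gives a 1.5-fold higher number from compound 1 to compound 4 (0.17 log units; within the scatter), so this exchange on the ring has no effect that can be told from the scatter. Compound 2 still has only a limit and no number, so the full size of the gain to compound 4 stays unknown: the limit of > 40000 nM in this assay, at which 1 of the 4 values shown sits.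

The compounds shown leave open whether an unsubstituted phenyl or an open chain such as butyl would sit with the substituted phenyl compounds or with compound 2. They also leave open how an amine or a carboxylic acid on the phenyl ring would fare.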